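Working notes: from compound 2 to compound 3

The compounds below may be only part of what the source reports. "The series", "measured", "known", "first", "only" and "open" are said of these compounds alone.

Compound 1 `O=C1OC[C@H](Cc2ccccc2)[C@H]1Cc1ccc(Cl)c(Cl)c1` gives 19000 nM
Compound 2 `O=C1OC[C@H](Cc2cccc(O)c2)[C@H]1Cc1ccc(Cl)c(Cl)c1` gives 48000 nM
Compound 3 `COc1ccc(C[C@H]2COC(=O)[C@@H]2Cc2ccc(Cl)c(Cl)c2)cc1` is not yet measured

For the measured compounds named here, in a functional assay on HL-60 cells (Homo sapiens) for cytotoxicity, read by WST assay, with a stated time of 48 h (on this read-out lower numbers stand for an effect already at smaller amounts and higher numbers for an effect only at larger amounts of compound), compound 2 holds the higher of the two numbers so far, and compound 1 is its only neighbour. The change now in question is 4-methoxyphenyl in place of 3-hydroxyphenyl on a saturated chain carbon bound to a saturated ring carbon, with 4-methoxyphenyl in place of 3-hydroxyphenyl on a saturated chain carbon bound to a saturated ring carbon. Going by the values given here, one measured step bears on it: a 2.5-fold higher number from compound 1 to compound 2 (0.40 log units; beyond the scatter), a modest step in which hydroxy took the place of hydrogen on an aromatic carbon. Compound 3 no longer carries that hydroxy, so that step may largely be reversed. Among the compounds with values here, no measured compound carries 4-methoxyphenyl, however, so what this group adds is unknown and the range stays wide. Within the data shown here, a modest move toward a lower number in this assay is therefore expected, of about the size of the one measured step. The estimated step is a 2.1-fold lower number from compound 2 to compound 3 (0.32 log units; beyond the scatter). The estimate for compound 3 is 23000 nM, with an expected range from 9000 nM to 55000 nM.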

Compound 3, half-maximal effective concentration: 37000 nM
Compound 3: the middle estimate sits 1.6-fold (0.21 log units) below what was measured, and the stated range covers the measured number.
By their numbers in this assay, from the lowest: compounds 1, 3 and 2 (each within the scatter of the next, the first and the last beyond it).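

In this assay the exchange of 3-hydroxyphenyl for 4-methoxyphenyl on a saturated chain carbon bound to a saturated ring carbon gives a 1.3-fold lower number from compound 2 to compound 3 (0.11 log units; within the scatter) and so does not separate the two groups. The methoxy group on its own gives a 1.9-fold higher number from compound 1 to compound 3 (0.29 log units; within the scatter) and likewise does not separate compound 3 from compound 1, so at this place only the hydroxy step, a 2.5-fold higher number from compound 1 to compound 2 (0.40 log units; beyond the scatter) remains beyond the scatter, and compound 3 lies within the scatter of both neighbours. Nothing on hand accounts for this result.

The exchange from compound 2 to compound 3 alters both the group, hydroxy against methoxy, and the number in its name, and the compounds shown do not tell these two changes apart. From the compounds shown here alone, whether an amine or a carboxylic acid on an aromatic carbon, or a longer chain at this place, would move the number in this assay beyond the scatter of these three compounds stays open.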